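This account rests on a few compounds, and the source may have more. Where it says the series, first, only, none or still open, it means among the compounds named here.

Series notes, lipophilicity set. Compound 1 `CCCCCOC(=O)c1ccc(S(N)(=O)=O)cc1` gives 2.71 in a physicochemical assay for lipophilicity; a higher number here means a more lipophilic compound, a lower number a more polar compound. Compound 2 `CCCCCCOC(=O)c1ccc(S(N)(=O)=O)cc1` gives 3.23 in this assay. The change between the two, (methyl in place of hydrogen on a saturated chain carbon, five bonds along the chain from an oxygen next to a carbonyl group), carries a step of a number 0.52 log units higher from compound 1 to compound 2 (beyond the scatter), and this is the only measured pair of this kind in the set.

Compound 3 `CCOC(=O)c1cccc(S(N)(=O)=O)c1` is built on a different core; how the core of compound 3 differs from the core of compound 1 is not broken down here. In this assay compound 3 gives 1.11, the lowest of the three numbers, with compound 1 and compound 2 both standing beyond the scatter above it.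

Compound 4 `CCCOC(=O)c1cccc(S(N)(=O)=O)c1` is not yet measured. It differs from compound 3 by methyl in place of hydrogen on a saturated chain carbon, two bonds along the chain from an oxygen next to a carbonyl group. Within the data shown here, this is the same kind of change as the one from compound 1 to compound 2, not the same: there the methyl enters five bonds along the chain from the oxygen next to the carbonyl group, here two bonds along the chain from that oxygen. Among the measured compounds shown here, the shared core of compound 3 and compound 4 has no second measured pair, so any expectation rests on the single measured step.

Compound 4 is expected to give about 1.6 in this assay, with a likely range from 1.3 to 1.9. The expected step of a number 0.49 log units higher from compound 3 to compound 4 (beyond the scatter) is set to match the measured a number 0.52 log units higher from compound 1 to compound 2 (beyond the scatter), allowing for the different place along the chain. Measurement pending.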

Compound 4, partition coefficient: 1.72
The estimate for compound 4 lay 0.12 log units below the measured number; the measured number falls inside the stated range.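

In this assay, methyl in place of hydrogen on a saturated chain carbon gives a number 0.61 log units higher from compound 3 to compound 4 (beyond the scatter) on one core, and a number 0.52 log units higher from compound 1 to compound 2 (beyond the scatter) on the other, so across these two pairs the change carries from one core to the other with a step of the same direction, beyond the scatter on both. Among these compounds, this does not establish a constant increment or a rule for other cores: there are only two pairs, and they differ in both core and place, with the methyl entering two bonds along the chain from the oxygen next to the carbonyl group in one pair and five bonds along it in the other, so the effects of core and place cannot be separated. Nothing at hand explains the size of either step.

The compounds shown leave open whether the same step would hold with the methyl entering at one fixed place on both cores, and whether it would persist on a longer chain built on the core of compound 3. They also leave open how this assay would respond if an amine or a carboxylic acid entered in place of methyl on either core.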